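The compounds below may be only part of what the source reports. "The series", "measured", "known", "first", "only" and "open" are said of these compounds alone.

Compound 1 `O=C(CN1CCN(C(=O)c2ccc(Cl)cc2)CC1)N1CCN(CCCc2c[nH]c3ccc(F)cc23)CC1`: 125000 nM
Compound 2 `O=C(CN1CCN(C(=O)c2ccc(F)cc2)CC1)N1CCN(CCCc2c[nH]c3ccc(F)cc23)CC1`: 121000 nM

In an ADME assay on SH-SY5Y cells (Homo sapiens) for cytotoxicity, read by MTT assay, with a stated time of 72 h (on this read-out higher numbers stand for weaker inhibition and lower numbers for stronger inhibition), compound 2 gives 121000 nM. This is level, within the scatter, with compound 1 at 125000 nM, so neither compound stands apart from the other.

The next compound is compound 3 `O=C(CN1CCN(C(=O)c2cccc(Cl)c2)CC1)N1CCN(CCCc2c[nH]c3ccc(F)cc23)CC1`, which has 3-chlorophenyl in place of 4-fluorophenyl on a carbonyl carbon.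

For the measured compounds named here, only one measured step bears on this change: a 1.0-fold lower number from compound 1 to compound 2 (0.01 log units; within the scatter). It exchanges chloro and fluoro on an aromatic carbon and stays within the scatter, which suggests that this halogen swap alone need not shift the number. Going by the values given here, no measured compound carries a 3-chlorophenyl group, so that part of the change remains untested.

In this assay, an estimated 1.0-fold lower number from compound 2 to compound 3 (0.00 log units; within the scatter) is expected, which means no step beyond the scatter. For compound 3 the estimated value is 120000 nM, with an expected range of 70000 nM to 200000 nM.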

Compound 3, half-maximal inhibitory concentration: 59800 nM
The estimate for compound 3 lay 2.0-fold (0.30 log units) above the measured number, and the stated range ends above it.
By their numbers in this assay, from the lowest: compound 3; then compounds 2 and 1 (each within the scatter of the next).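

In this assay, 3-chlorophenyl in place of 4-chlorophenyl gives a 2.1-fold lower number from compound 1 to compound 3 (0.32 log units; beyond the scatter) with the same halogen on the ring, so where the chlorine sits on the ring can shift this number modestly. Likewise, 3-chlorophenyl in place of 4-fluorophenyl gives a 2.0-fold lower number from compound 2 to compound 3 (0.31 log units; beyond the scatter) at the same place on the carbonyl carbon. Since compound 1 and compound 2 stayed level within the scatter, these three compounds link the shift to the 3-chlorophenyl group rather than to the choice between the two halogens in the earlier pair.

Going by these compounds, it remains open whether a 3-fluorophenyl, a 3-methoxyphenyl or a 2-chlorophenyl group would give a similar number. No measurement offered here explains why the 3-chlorophenyl compound gives the lower number.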